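The source may hold more compounds than are shown below. What is called first, only, known or untested is meant among the compounds shown, and "the series" means these compounds.

Of the compounds shown here, three sharing one core have been measured in a functional assay on HT-29 cells (Homo sapiens) for cytotoxicity, read by MTT assay, with a stated time of 24 h, tested at 16 ug/mL; a higher number here means a stronger effect of the compound at the concentration tested, a lower number a weaker effect. Compound 1 `Cc1ccc2oc(SCC(=O)Nc3ccc(-c4nc(-c5ccccc5)c(-c5ccccc5)n4C)cc3)nc2c1` gives 37.7%, compound 2 `Cn1c(-c2ccc(NC(=O)CSc3nc4ccccc4s3)cc2)nc(-c2ccccc2)c1-c1ccccc1` gives 47.2%, and compound 3 `Cc1nnc(SCC(=O)Nc2ccc(-c3nc(-c4ccccc4)c(-c4ccccc4)n3C)cc2)s1` gives 83.3%. Compound 2 therefore stands between the other two, within the scatter of compound 1, since a number 9.5 percentage points higher from compound 1 to compound 2 (within the scatter), while the step of a number 36.1 percentage points higher from compound 2 to compound 3 (beyond the scatter) and the step of a number 45.6 percentage points higher from compound 1 to compound 3 (beyond the scatter) are both large. Compound 4 `CN(C)/C=C/N1CCN(CC(=O)Nc2ccc(-c3nc(-c4ccccc4)c(-c4ccccc4)n3C)cc2)CC1` differs from compound 2 by 4-(2-(dimethylamino)ethenyl)piperazin-1-yl in place of (1,3-benzothiazol-2-yl)sulfanyl on a saturated chain carbon bound to a carbonyl carbon. Going by the values given here, the measured steps all exchange one heteroaryl for another on the sulfur; none removes the sulfanyl group itself, so no measured step bears directly on this change. Compound 4 is expected to give about 40%, between 15% and 70%, meaning an estimated step of a number 7.2 percentage points lower from compound 2 to compound 4 (within the scatter).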

Compound 4, a percentage reported as activity, at one concentration (the size of the read-out at that concentration, not a potency): 28.2%
The estimate for compound 4 lay 11.8 percentage points above the measured number, and the stated range covers the measured number.
By their numbers in this assay, from the lowest: compounds 4, 1 and 2 (each within the scatter of the next, the first and the last beyond it); then compound 3.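

At the saturated chain carbon bound to a carbonyl carbon, the exchange now reaches beyond heteroaryl groups on a sulfur, and in this assay its size depends on which group leaves: a number 55.1 percentage points lower from compound 3 to compound 4 (beyond the scatter) and a number 19 percentage points lower from compound 2 to compound 4 (beyond the scatter) stand against a number 9.5 percentage points lower from compound 1 to compound 4 (within the scatter) for the same entering group. No measured evidence explains these steps. The compounds shown leave open whether the piperazine ring or its 2-(dimethylamino)ethenyl group governs the read-out, and what an unsubstituted piperazin-1-yl or a morpholin-4-yl would give on this carbon.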